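Swapping Fluoro for Chloro on a Sulfonamide Aryl Ring

A few compounds are considered here, and "the series" means these few. Any claim that something is new, unique, unknown or untested is made for them only; others in the source may bear on it.

Of the compounds shown here, three have been measured in an assay on cells for inhibition of HSP60/HSP10 (Homo sapiens), with a stated time of 60 min; a lower number here means a stronger inhibitor, a higher number a weaker inhibitor. Compound 1, `O=S(=O)(Nc1ccc(-c2nc3ccccc3o2)cc1)c1ccc(F)c(C(F)(F)F)c1`, gives 28000 nM in this assay, the lowest of the three numbers. Among the compounds with values here, compound 3, `CS(=O)(=O)Nc1ccc(-c2nc3cc(NS(=O)(=O)c4ccc(Cl)s4)ccc3o2)cc1`, gives 43000 nM, a number that lies within the usual scatter of the one for compound 1, so the two cannot be ranked against each other. Compound 2, `O=S(=O)(Nc1ccc2oc(-c3ccccc3)nc2c1)c1ccccc1O`, gives 85000 nM, a number that sits beyond the scatter above that of compound 1. Within the data shown here, none of the three measured compounds differs from another in a single place, so no step between measured compounds is available to guide the next one.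

Compound 4, `O=S(=O)(Nc1ccc(-c2nc3ccccc3o2)cc1)c1ccc(Cl)c(C(F)(F)F)c1`, has not yet been measured. It differs from compound 1 in one place: chloro in place of fluoro on an aromatic carbon. Among the measured compounds shown here, with no measured step of this kind among the three compounds, the size of the step in this assay can only be judged from the change itself, one halogen exchanged for another with nothing else altered. The step is expected to be small, most likely none beyond the scatter, with a slight lean toward a lower number. Compound 4 is therefore expected to give about 20000 nM, between 8000 nM and 50000 nM. This estimate corresponds to an expected step of a 1.4-fold lower number from compound 1 to compound 4 (0.15 log units; within the scatter).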

Compound 4, half-maximal inhibitory concentration: 12000 nM
Compound 4: middle estimate off by 1.7-fold (0.22 log units), on the high side; low and high end bracket the measured number.
By their numbers in this assay, from the lowest: compound 4; then compounds 1, 3 and 2 (each within the scatter of the next, the first and the last beyond it).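

Within the data shown here, the exchange of fluoro for chloro, on an aromatic carbon ortho to a trifluoromethyl group, gives the first comparison in this assay between two compounds that differ in one place, and it reads as a 2.3-fold lower number from compound 1 to compound 4 (0.37 log units; beyond the scatter). This position therefore responds to the replacement of a single halogen atom, with a step beyond the scatter, even though no ring, hydrogen-bond donor, hydrogen-bond acceptor or net charge enters or leaves with the change. Nothing available explains why chloro gives the lower number at this carbon.

The compounds shown leave open whether a bromo group, a methyl group or a plain hydrogen on this same carbon would lower the number further or raise it again, as the single step covers only two halogens. Also open, from the compounds shown here alone, is whether the same exchange would give a step of similar size without the trifluoromethyl group, or on the core of compound 2 or compound 3.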